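This account rests on a few compounds, and the source may have more. Where it says the series, first, only, none or still open, it means among the compounds named here.

Measured so far:
compound 1 `CCOC(=O)C1=Cc2ccccc2OC1(OCc1cc(-c2ccc(F)cc2F)no1)C(F)(F)F` gives > 150000 nM
compound 2 `CCOC(=O)C1=Cc2ccccc2OC1(OCc1cn(CC(=O)Nc2ccc(OC)cc2)nn1)C(F)(F)F` gives 31900 nM

Both compounds share one core and differ only in the group hanging from the ether oxygen. In a functional assay on HeLa cells (Homo sapiens) for inhibition, read by MTT assay, with a stated time of 24 h (a higher number here means a weaker inhibitor, a lower number a stronger inhibitor), compound 2 gives 31900 nM. Compound 1 does not give a number in this assay at all: its result, > 150000 nM, is a limit of the assay. Where compound 1 stands is therefore fixed only by the limit of > 150000 nM in this assay, at which 1 of the 2 values shown sits, so it can be placed no closer than at the weak end of what the method reports.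

Compound 3 `CCOC(=O)C1=Cc2ccccc2OC1(OCc1cc(-c2ccc(Br)cc2)no1)C(F)(F)F` is the untested partner of compound 1. The change is 4-bromophenyl in place of 2,4-difluorophenyl on an aromatic carbon. Within the data shown here, no measured pair that differs in a single place is available here, so the size of a step in this assay from such a change is not known from these data. The expected step is a number no higher from compound 1 to compound 3 (the limit leaves the size open), which means little movement beyond the usual scatter. Compound 3 is therefore expected to give about 150000 nM, within a range from 50000 nM to 450000 nM, with a fair chance that this assay again reports only a limit.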

Compound 3, half-maximal inhibitory concentration: 52300 nM
The estimate for compound 3 lay 2.9-fold (0.46 log units) above the measured number; the measured number falls inside the stated range.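

Compound 1 and compound 3 form the only pair shown that differs in a single place, so the aromatic carbon of the five-membered aromatic ring with 1 nitrogen and 1 oxygen can now be judged on its own. In this assay, 4-bromophenyl in place of 2,4-difluorophenyl at this carbon gives an at least 2.8-fold lower number from compound 1 to compound 3 (0.45 log units; beyond the scatter) and shows that the choice of phenyl group here can change the result while the rest of the molecule stays the same. As far as these compounds go, compound 1 gives > 150000 nM as a limit of the assay and not as a number, and the true size of the step remains unknown because this step starts from that limit: the limit of > 150000 nM in this assay, at which 1 of the 3 values shown sits.

This single change removes two fluorine atoms and adds one bromine atom, so the pair cannot tell whether the loss of fluorine, the arrival of bromine, or both account for the step. A plain phenyl, a 4-fluorophenyl or a 4-chlorophenyl group at the same carbon would help separate these possibilities, while a phenyl ring bearing an amine or a carboxylic acid would test a quite different kind of group there.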